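This account rests on a few compounds, and the source may have more. Where it says the series, first, only, none or still open, it means among the compounds named here.

Measured so far in an ADME assay on microsomes from liver (Rattus norvegicus) for metabolic stability, read by LC-MS, using NADPH, with a stated time of 90 min, tested at 1 uM; on this read-out higher numbers stand for a longer-lived compound and lower numbers for a shorter-lived compound:

compound 1 `Fc1ccc(N2CCN(CCCc3c[nH]c4ccc(F)cc34)CC2)c(-c2ccoc2)c1`: 0.172 h
compound 2 `Fc1ccc2c(C3CCN(CCCc4c[nH]c5ccc(F)cc45)CC3)noc2c1`: 0.0767 h
compound 3 `Fc1ccc(C2CCN(CCCc3c[nH]c4ccc(F)cc34)CC2)c(-c2ccsc2)c1`: 0.306 h

Compound 1 gives the second highest of the three half-lives. Its nearest neighbour is compound 3, whose value lies within the usual scatter of the value of compound 1, so the two cannot be told apart on this read-out. Compound 2 lies furthest away, with a value below that of compound 1 and beyond the scatter, so compound 2 is the shorter-lived of that pair.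

Compound 4 `Cn1cc(-c2cc(F)ccc2N2CCN(CCCc3c[nH]c4ccc(F)cc34)CC2)cn1` is the next member of the series to be run in this assay. It differs from compound 1 in one place: 1-methyl-1H-pyrazol-4-yl in place of furan-3-yl on an aromatic carbon. Among the compounds with values here, no measured pair in the set shows this exchange, so there is no step to lean on. The expectation is a small upward step from compound 1 to compound 4, a 1.5-fold higher number from compound 1 to compound 4 (0.16 log units; within the scatter), which may well stay within the scatter. On that basis compound 4 is estimated at 0.25 h, with a likely range from 0.1 h to 0.6 h.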

Compound 4, half-life: 0.158 h
The estimate for compound 4 lay 1.6-fold (0.20 log units) above the measured number, and the stated range covers the measured number.
By their numbers in this assay, from the lowest: compound 2; then compounds 4, 1 and 3 (each within the scatter of the next).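

In this assay, 1-methyl-1H-pyrazol-4-yl in place of furan-3-yl on an aromatic carbon, ortho to a large group and meta to a fluoro group, gives a 1.1-fold lower number from compound 1 to compound 4 (0.04 log units; within the scatter) and leaves compound 1 and compound 4 indistinguishable on half-life. Within the data shown here, this is the only measured exchange at this place, and it shows that a five-membered aromatic ring with 2 hetero atoms and 6 heavy atoms can replace one with 1 hetero atom and 5 heavy atoms without a readable difference. No available evidence bears on the origin of this result.

The compounds shown leave open what a carboxylic acid or a primary amine on this aromatic carbon would do to the half-life. They also leave open whether a phenyl ring there would match the two five-membered rings.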